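The compounds below may be only part of what the source reports. "The series", "measured", "known", "first", "only" and "open" are said of these compounds alone.

Compound 1 `NC(=O)c1cc(Cl)ccc1NC(=O)COc1ccccc1`: 87%
Compound 2 `Cc1ccc(NC(=O)COc2ccccc2)c(C(N)=O)c1`: 72%

For the measured compounds named here, in a functional assay on K562 cells (Homo sapiens) for inhibition, read by trypan blue exclusion, with a stated time of 24 h, tested at 10 uM (on this read-out lower numbers stand for less inhibition of growth and higher numbers for more inhibition of growth at the one concentration tested), compound 2 gives 72%, the lower of the two numbers measured so far, and compound 1, its nearest neighbour, stands higher by more than the scatter. The next compound is compound 3 `COc1ccc(NC(=O)COc2ccccc2)c(C(N)=O)c1`. It differs from compound 2 in one place: methoxy in place of methyl on an aromatic carbon.

Going by the values given here, only one measured step bears on this. It is a number 15 percentage points lower from compound 1 to compound 2 (beyond the scatter), a modest change with methyl in place of chloro on an aromatic carbon. Among the compounds with values here, that step shows that a swap of this kind can move the number, but no measured compound carries methoxy, so the direction stays open. The expected step is a number 3 percentage points higher from compound 2 to compound 3 (within the scatter), which means no change beyond the scatter is expected. For compound 3 the estimate is 75%, with an expected range from 60% to 88%.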

Compound 3, percent growth inhibition at one concentration: 85.3%
Beside the measured number, compound 3's estimate is 10.3 percentage points below it, within the range that was stated.
By their numbers in this assay, from the lowest: compound 2; then compounds 3 and 1 (each within the scatter of the next).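

Changing methyl to methoxy at this position, meta to a carbamoyl group and para to a large group, gives a number 13.3 percentage points higher from compound 2 to compound 3 (beyond the scatter) in this assay and shows that the number here can rise as well as fall. Methoxy in place of chloro gives a number 1.7 percentage points lower from compound 1 to compound 3 (within the scatter) so these two groups cannot be told apart on this read-out, while methyl stands apart from both. Nothing at hand accounts for this difference.

Still open, on these data alone, is how an amine, a hydroxyl group, a carboxylic acid or a longer chain such as ethoxy would behave at this position. As far as these compounds go, each number also comes from a single concentration, so how these compounds would rank across a range of concentrations remains unknown.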